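A few compounds are considered here, and "the series" means these few. Any claim that something is new, unique, unknown or untested is made for them only; others in the source may bear on it.

Three compounds of the series carry numbers in an assay on Sf9 cells for inhibition of protein deacetylase HDAC6 (Homo sapiens), read by fluorescence, with a stated time of 40 min, tested at 100 nM; on this read-out higher numbers stand for more inhibition at the one concentration tested (going by the name of the read-out) and lower numbers for less inhibition: compound 1 `O=C(NO)c1ccc(NCc2nc(-c3ccc(Br)o3)nn2-c2ccccc2)cc1` gives 55.8%, compound 2 `O=C(NO)c1ccc(NCc2nc(-c3ccco3)nn2-c2ccccc2)cc1` gives 59.9%, and compound 3 `O=C(NO)c1ccc(NCc2nc(-c3cccnc3)nn2-c2ccccc2)cc1` gives 57.7%. Compound 3 stands second highest of the three; its nearest number is told by a number 1.9 percentage points higher from compound 1 to compound 3 (within the scatter) and its furthest by a number 2.2 percentage points lower from compound 2 to compound 3 (within the scatter). Compound 4 `O=C(NO)c1ccc(NCc2nc(-c3ccc(Cl)cc3)nn2-c2ccccc2)cc1` is not yet measured. The change is 4-chlorophenyl in place of pyridin-3-yl on an aromatic carbon. Among the measured compounds shown here, the steps that bear on it are the exchanges of the group at the same carbon, a number 4.1 percentage points higher from compound 1 to compound 2 (within the scatter) together with the two steps already named, all within the scatter. A step of a number 0.7 percentage points lower from compound 3 to compound 4 (within the scatter) is therefore expected, none beyond the scatter. Compound 4 is estimated at 57%, between 45% and 69%.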

Compound 4, a percentage reported as inhibition, at one concentration (the size of the read-out at that concentration, not a potency): 67.2%
Compound 4: middle estimate off by 10.2 percentage points, on the low side, and the stated range covers the measured number.
By their numbers in this assay, from the lowest: compounds 1, 3, 2 and 4 (each within the scatter of the next, the first and the last beyond it).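

In this assay the exchange at this aromatic carbon yields its first step beyond the scatter, a number 11.4 percentage points higher from compound 1 to compound 4 (beyond the scatter) and so only modest in size. The steps of a number 9.5 percentage points higher from compound 3 to compound 4 (within the scatter) and a number 7.3 percentage points higher from compound 2 to compound 4 (within the scatter) stay within the scatter, so 4-chlorophenyl stands apart only from 5-bromofuran-2-yl. Nothing on hand gives a reason for this step.

Still open, on these data alone, is whether the step follows the chlorine or the carbon-only ring. Phenyl without the chlorine, 4-fluorophenyl or 4-methoxyphenyl at this carbon would separate the two.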